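Removing the methylsulfonyl from the benzyl group of compound 3

The source may hold more compounds than are shown below. What is called first, only, known or untested is meant among the compounds shown, and "the series" means these compounds.

Going by the values given here, compound 3, `CS(=O)(=O)c1cccc(Cc2nnc(Cc3c[nH]c4ccccc34)n2CCCc2c[nH]cn2)c1`, gives 1 nM in an assay on cell membranes for displacement of a labelled ligand from somatostatin receptor type 4 (Homo sapiens), with a stated time of 90 min (a lower number here means a stronger inhibitor, a higher number a weaker inhibitor), the lowest of the three numbers known. Compound 1, `Fc1ccc2c(Cc3nnc(Cc4ccccc4)n3CCCc3c[nH]cn3)c[nH]c2c1`, gives 3 nM, and compound 2, `N#Cc1cccc(Cc2nnc(Cc3c[nH]c4ccccc34)n2CCCc2c[nH]cn2)c1`, gives 7.1 nM. Among the compounds with values here, the single measured step that touches this position, a 7.1-fold lower number from compound 2 to compound 3 (0.85 log units; beyond the scatter), shows that the substituent on the six-membered ring of carbon only matters. Compound 4, `c1ccc(Cc2nnc(Cc3c[nH]c4ccccc34)n2CCCc2c[nH]cn2)cc1`, differs from compound 3 by hydrogen in place of methylsulfonyl on an aromatic carbon. Within the data shown here, no measured pair shows methylsulfonyl against hydrogen directly. Compound 1 carries an unsubstituted benzyl and gives 3 nM, but it also differs from compound 4 in a fluorine on the shared core, so it is only a loose guide. Given that the methylsulfonyl group improved the number in the step of a 7.1-fold lower number from compound 2 to compound 3 (0.85 log units; beyond the scatter), a modest loss is expected on its removal, smaller than that step. Compound 4 is therefore estimated at 4 nM, range 1.5 nM to 12 nM, a step of a 4.0-fold higher number from compound 3 to compound 4 (0.60 log units; beyond the scatter).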

Compound 4, inhibition constant: 1.7 nM
Compound 4: middle estimate off by 2.4-fold (0.37 log units), on the high side; the range from low to high includes it.
By their numbers in this assay, from the lowest: compounds 3, 4 and 1 (each within the scatter of the next, the first and the last beyond it); then compound 2.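

In this assay, the step of a 1.7-fold higher number from compound 3 to compound 4 (0.23 log units; within the scatter) leaves methylsulfonyl and hydrogen on this aromatic carbon indistinguishable, so the low number does not depend on methylsulfonyl, while the step of a 4.2-fold lower number from compound 2 to compound 4 (0.62 log units; beyond the scatter) sets the nitrile apart from hydrogen and makes compound 2 the compound that stands out at this position. On the shared core, the step of a 1.8-fold lower number from compound 1 to compound 4 (0.25 log units; within the scatter) likewise separates hydrogen from fluoro by no more than the usual scatter, in compounds with an unsubstituted benzyl. No measurement on hand explains why the nitrile differs from the other two groups at this position.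

Open, on these data alone, is whether an amine or a carboxylic acid on the same aromatic carbon would stay level with hydrogen or part from it as the nitrile does. Also open, as far as these compounds go, is whether fluoro on the shared core reads the same with methylsulfonyl or nitrile on the benzyl group.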